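A few compounds are considered here, and "the series" means these few. Any claim that something is new, unique, unknown or untested is made for them only; others in the source may bear on it.

Compound 2 `CCC(COc1cccc(C#N)c1)OC(=O)NCc1ccccc1` carries a 3-cyanophenyl group on the oxygen that sits on a saturated carbon. In an assay for inhibition of zeta-carotene desaturase, chloroplastic/chromoplastic (Capsicum annuum), using a Dixon plot, with a stated time of 8 h (a lower number here means a stronger inhibitor, a higher number a weaker inhibitor), compound 2 gives > 100000 nM, which is a limit of the assay rather than a number. Compound 1 `CCC(COc1cccc(Br)c1)OC(=O)NCc1ccccc1` gives > 100000 nM in this assay, also a limit. Compound 3 `CCC(COc1cccc(NC(C)=O)c1)OC(=O)NCc1ccccc1` gives > 100000 nM in this assay, a limit as well. Hence the three measured steps are all unreadable: a step that the two limits leave unreadable from compound 1 to compound 2, a step that the two limits leave unreadable from compound 1 to compound 3 and a step that the two limits leave unreadable from compound 2 to compound 3 cannot be sized because of the limit of > 100000 nM in this assay, at which 3 of the 3 values shown sit.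

Compound 4 `CCC(COc1ccc(Cl)c(Cl)c1)OC(=O)NCc1ccccc1` arises from compound 2 through (3,4-dichlorophenyl in place of 3-cyanophenyl on an oxygen on a saturated carbon). Going by the values given here, none of the measured steps gives a readable size for any change of the group on that oxygen, so the direction of the step to compound 4 in this assay cannot be inferred from them, and compound 4 is expected to behave like its three neighbours and sit at the same limit. Compound 4 is therefore estimated at 100000 nM, with a range from 20000 nM to 300000 nM. That expectation corresponds to a step of a number no higher from compound 2 to compound 4 (the limit leaves the size open) in this assay.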

Compound 4, half-maximal inhibitory concentration: > 100000 nM
Compound 4 ended at the assay's limit; the forecaster's own chance of this, stated with the estimate: 85%; the middle value lies on the limit itself.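

In this assay compound 4 gives > 100000 nM, which is a limit of the assay. No size can be read for the steps to it from compound 1 and compound 2. The compounds shown leave open whether any group on an oxygen on a saturated carbon changes inhibition, and by how much.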